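Chain-shortening step in a cytotoxicity series

The compounds below may be only part of what the source reports. "The series", "measured", "known", "first", "only" and "open" are said of these compounds alone.

Compound 1 `CC(C)[S+]([O-])CCCCN=C=S` and compound 2 `[O-][S+](CCCCN=C=S)Cc1ccccc1` carry different groups on the sulfur; the difference between the two cores is not broken down here. In a functional assay on HCT-116 cells (Homo sapiens) for cytotoxicity, read by MTT assay, with a stated time of 72 h (on this read-out higher numbers stand for weaker inhibition and lower numbers for stronger inhibition), compound 1 gives 3740 nM and compound 2 gives 3660 nM; the two numbers lie within the usual scatter of each other, so no order between them is drawn. Compound 3 `[O-][S+](CCCN=C=S)Cc1ccccc1` carries a group of 3 heavy atoms (1 carbon, 1 nitrogen, 1 sulfur; no ring) in place of a group of 4 heavy atoms (2 carbon, 1 nitrogen, 1 sulfur; no ring), on a saturated chain carbon, three bonds along the chain from a sulfur relative to compound 2, and in this assay compound 3 gives 15600 nM. The change amounts to a 4.3-fold higher number from compound 2 to compound 3 (0.63 log units; beyond the scatter).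

Compound 4 `CC(C)[S+]([O-])CCCN=C=S` stands to compound 1 as compound 3 stands to compound 2: it carries a group of 3 heavy atoms (1 carbon, 1 nitrogen, 1 sulfur; no ring) in place of a group of 4 heavy atoms (2 carbon, 1 nitrogen, 1 sulfur; no ring), on a saturated chain carbon, three bonds along the chain from a sulfur, and the place of the change is worded identically in both pairs, so this is the same change, made on the core of compound 1 rather than on the core of compound 2. Within the data shown here, only one measured instance of the change exists, in the pair from compound 2 to compound 3, and compound 1 and compound 2 start from numbers that are within scatter of each other, which is all the expectation for compound 4 can rest on. Because a 4.3-fold higher number from compound 2 to compound 3 (0.63 log units; beyond the scatter) is that single instance, compound 4 is expected to show a 4.3-fold higher number from compound 1 to compound 4 (0.63 log units; beyond the scatter) in this assay. Compound 4 is accordingly estimated at 16000 nM, with an expected range from 8000 nM to 32000 nM.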

Compound 4, half-maximal inhibitory concentration: 15900 nM
Compound 4: the middle estimate sits 1.0-fold (0.00 log units) above what was measured, and the stated range covers the measured number.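

In this assay the shorter chain gives a 4.3-fold higher number from compound 1 to compound 4 (0.63 log units; beyond the scatter), and the step on the core of compound 1 matches the one on the core of compound 2, so the change carries over between these two cores with no difference beyond the scatter: the same change on two cores in this assay, a 4.3-fold higher number (0.63 log units; beyond the scatter) from compound 2 to compound 3 and a 4.3-fold higher number (0.63 log units; beyond the scatter) from compound 1 to compound 4, 1.0-fold (0.00 log units) apart, within the scatter of two such steps. The agreement supports treating the exchange of the group of 4 heavy atoms for the group of 3 heavy atoms as transferable within this small set, on a saturated chain carbon, three bonds along the chain from a sulfur, and in this one cellular read-out. It rests on two pairs only, whose starting numbers lie within the scatter of each other, so it does not show that the step keeps its size on a core with a clearly different starting number, and it gives no reason for the loss of inhibition on shortening.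

Going by these compounds, a longer chain remains open, including whether the numbers keep falling or level off beyond the group of 4 heavy atoms. Also open, on these data alone, is how the series responds when a nitrile or an amine stands at the chain end, or when a carboxylic acid is carried on the group attached to the sulfur.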